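The source may report more compounds than this note shows. Statements on the series, on what has been measured and on what is new or still open speak of the compounds shown alone.

Of the compounds shown here, two built on the same core have been measured, and a third awaits its result. Compound 1 `CC(Oc1ccccc1Br)C1=NCCN1` carries a bromo group on an aromatic carbon, and in a functional assay on CHO cells for agonist activity at Alpha-2B adrenergic receptor (Homo sapiens) (a higher number here means that more compound is needed for the effect, a lower number that less compound is needed), compound 1 gives 316 nM. Compound 2 `C=C(C)c1ccccc1OC(C)C1=NCCN1` carries a 1-methylethenyl group in its place, and in this assay compound 2 gives 1580 nM. For the measured compounds named here, the single measured step, a 5.0-fold higher number from compound 1 to compound 2 (0.70 log units; beyond the scatter), is the only change seen so far. Compound 2 therefore stands as the higher of the two numbers, its nearest neighbour being compound 1 with the lower one.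

Compound 3 `CCOc1ccccc1OC(C)C1=NCCN1` differs from compound 2 by ethoxy in place of 1-methylethenyl on an aromatic carbon. Going by the values given here, no measured step replaces a 1-methylethenyl group with an ethoxy group, so the step from compound 1 to compound 2 bears on it only in showing that a change at this aromatic carbon can move the number by a modest amount. Among the compounds with values here, with that as the only guide, compound 3 is expected to give a number close to that of compound 2, with at most a small movement downward, so the expected step is a 1.6-fold lower number from compound 2 to compound 3 (0.20 log units; within the scatter). The estimate for compound 3 in this assay is 1000 nM, with a range from 200 nM to 5000 nM.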

Compound 3, half-maximal effective concentration: 3160 nM
Estimate against measurement, compound 3: 3.2-fold (0.50 log units) below; low and high end bracket the measured number.
By their numbers in this assay, from the lowest: compound 1; then compounds 2 and 3 (each within the scatter of the next).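

The swap of 1-methylethenyl for ethoxy on this aromatic carbon gives a 2.0-fold higher number from compound 2 to compound 3 (0.30 log units; within the scatter), so in this assay the two groups cannot be told apart, even though ethoxy carries an oxygen and a hydrogen-bond acceptor while 1-methylethenyl carries neither. The comparison with bromo is clearer: replacing it with ethoxy gives a 10-fold higher number from compound 1 to compound 3 (1.00 log units; beyond the scatter), and together with the earlier step to compound 2, this places compound 1 apart from both other compounds, each of which has a group of 3 heavy atoms at this place. These numbers show what happens at this aromatic carbon but not why, as no other measurement is available to explain them.

Going by these compounds, three groups at a single place cannot show whether bromo itself matters or whether other groups would do as well, so it remains open whether chloro, an amine or a longer chain such as butoxy would fall near compound 1 or near compound 3. On these data alone, it is also open whether the gap between bromo and ethoxy would stay the same if another part of the shared core were changed.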